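The compounds below may be only part of what the source reports. "The series", "measured", "known", "first", "only" and "open" are said of these compounds alone.

Compound 1 `COc1cc(C(=O)c2sc3ccccc3c2-c2ccc(Cl)cc2)cc(OC)c1OC`: 5200 nM
Compound 2 `COc1ccc(-c2c(C(=O)c3cc(OC)c(OC)c(OC)c3)sc3ccccc23)cc1`: 4200 nM
Compound 3 `COc1cc(C(=O)c2sc3ccccc3c2-c2ccc(SC)cc2)cc(OC)c1OC`: 3500 nM

These three were tested in a functional assay on HeLa cells (Homo sapiens) for antiproliferative activity, read by MTT assay, with a stated time of 72 h; a higher number here means a weaker inhibitor, a lower number a stronger inhibitor. There, compound 3 gives 3500 nM and is not separated from the other two, as the steps show: a 1.5-fold lower number from compound 1 to compound 3 (0.17 log units; within the scatter) and a 1.2-fold lower number from compound 2 to compound 3 (0.08 log units; within the scatter). Compound 4 `COc1ccc(OC)c(-c2c(C(=O)c3cc(OC)c(OC)c(OC)c3)sc3ccccc23)c1`, not yet measured, keeps the shared core but changes the aryl group: 2,5-dimethoxyphenyl in place of 4-(methylsulfanyl)phenyl on an aromatic carbon. The closest evidence is the exchange of chloro, methoxy and methylsulfanyl on that aryl group. Besides the two steps above, this includes a 1.2-fold lower number from compound 1 to compound 2 (0.09 log units; within the scatter). Among the compounds with values here, all three steps are small, but no measured compound carries two methoxy groups on that ring, so the data hold no direct precedent. No step beyond the scatter is therefore expected in this assay, in either direction, although the uncertainty is wide. The expected step is a 1.1-fold higher number from compound 3 to compound 4 (0.06 log units; within the scatter). Compound 4 is expected at 4000 nM, with an estimated range of 1500 nM to 10000 nM.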

Compound 4, half-maximal inhibitory concentration: 10000 nM
Compound 4: middle estimate off by 2.5-fold (0.40 log units), on the low side; the measured number falls inside the stated range.
By their numbers in this assay, from the lowest: compounds 3, 2, 1 and 4 (each within the scatter of the next, the first and the last beyond it).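

In this assay, within the data shown here, the aryl group at this position now matters for the first time: 2,5-dimethoxyphenyl in place of 4-(methylsulfanyl)phenyl gives a 2.9-fold higher number from compound 3 to compound 4 (0.46 log units; beyond the scatter) and in place of 4-methoxyphenyl gives a 2.4-fold higher number from compound 2 to compound 4 (0.38 log units; beyond the scatter) as the two steps that leave the scatter. Against 4-chlorophenyl the same exchange gives a 1.9-fold higher number from compound 1 to compound 4 (0.28 log units; within the scatter) and remains unresolved, so compound 4 is separated from only two of the three earlier compounds. No measurement shown here explains these steps.

The compounds shown leave open which of the two methoxy groups on that ring accounts for the steps, or whether both are needed. They also leave open how an aryl group carrying an amine or a hydroxyl would read in this assay.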